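Capping the hydroxy of compound 3 with isopropyl

The compounds below may be only part of what the source reports. "The series", "measured", "known", "first", "only" and "open" are said of these compounds alone.

In a functional assay (Left cardiac atrium, Cavia porcellus), with a stated time of 30 min (a higher number here means that more compound is needed for the effect, a lower number that less compound is needed), compound 1 `CC1=CSC(O)(c2ccccc2)c2noc(=O)n21` gives 230 nM, compound 2 `CC1=CSC(OCC2CCCCC2)(c2ccccc2)c2noc(=O)n21` gives 870 nM and compound 3 `COc1ccc(C2(O)SC=C(C)n3c2noc3=O)cc1` gives 520 nM. Compound 3 therefore lies within the usual scatter of compound 2 and clearly above compound 1. Compound 4 `COc1ccc(C2(OC(C)C)SC=C(C)n3c2noc3=O)cc1` changes hydroxy to isopropoxy: isopropyl in place of hydrogen on an oxygen on a saturated carbon. Among the measured compounds shown here, the closest precedent is cyclohexylmethyl in place of hydrogen on that same oxygen, which gave a 3.8-fold higher number from compound 1 to compound 2 (0.58 log units; beyond the scatter). The methoxy change, a 2.3-fold higher number from compound 1 to compound 3 (0.35 log units; beyond the scatter), is already built into compound 3 and bears on this step only indirectly. A similar or somewhat smaller rise is expected in this assay, and the expected step is a 2.1-fold higher number from compound 3 to compound 4 (0.33 log units; beyond the scatter). Compound 4 is estimated at 1100 nM, within an expected range of 450 nM to 2600 nM.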

Compound 4, half-maximal effective concentration: 430 nM
Compound 4: the middle estimate sits 2.6-fold (0.41 log units) above what was measured; the measured number lies below the stated range.
By their numbers in this assay, from the lowest: compounds 1, 4, 3 and 2 (each within the scatter of the next, the first and the last beyond it).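

Capping this oxygen does not always raise the number: in this assay, isopropyl in place of hydrogen gives a 1.2-fold lower number from compound 3 to compound 4 (0.08 log units; within the scatter). The earlier capping step, with cyclohexylmethyl on the core without methoxy, gave a 3.8-fold higher number from compound 1 to compound 2 (0.58 log units; beyond the scatter), so the oxygen tolerates at least one cap with no change beyond the scatter. Nothing measured here accounts for the contrast between these two steps. The compounds shown cannot separate the effect of the capping group from that of the methoxy. They also leave open how a plain methyl, a longer chain or a chain ending in an amine would behave on this oxygen.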